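Does a longer chain lower growth inhibition further?

A few compounds are considered here, and "the series" means these few. Any claim that something is new, unique, unknown or untested is made for them only; others in the source may bear on it.

In a functional assay on PC-3 cells (Homo sapiens) for inhibition, with a stated time of 48 h, tested at 50 uM (on this read-out lower numbers stand for less inhibition of growth and higher numbers for more inhibition of growth at the one concentration tested), compound 1 (`C=C[C@@](C)(/C=C/c1ccc(OC(=O)CCCC)cc1)CCC=C(C)C`) gives 42%, while compound 2 (`C=C[C@@](C)(/C=C/c1ccc(OC(=O)CCCCC)cc1)CCC=C(C)C`) gives 28%, the lower of the two numbers. Compound 3 (`C=C[C@@](C)(/C=C/c1ccc(OC(=O)CCCCCCC)cc1)CCC=C(C)C`) has not yet been measured. It differs from compound 2 as follows: ethyl in place of hydrogen on a saturated chain carbon, five bonds along the chain from a carbonyl carbon. Going by the values given here, only one measured step bears on this change: a number 14 percentage points lower from compound 1 to compound 2 (beyond the scatter). That step came from methyl in place of hydrogen on a saturated chain carbon, four bonds along the chain from a carbonyl carbon. One step cannot establish a trend, but it points to a further fall of similar size in this assay. The expected change is a number 12 percentage points lower from compound 2 to compound 3 (beyond the scatter). Compound 3 is estimated at 16%, with an expected range of 4% to 32%.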

Compound 3, percent growth inhibition at one concentration: 22%
Compound 3: middle estimate off by 6 percentage points, on the low side, within the range that was stated.
By their numbers in this assay, from the lowest: compounds 3 and 2 (each within the scatter of the next); then compound 1.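

Lengthening the chain further, with ethyl at this place, gives a number 6 percentage points lower from compound 2 to compound 3 (within the scatter) in this assay, so the clear fall seen on the first extension does not show up as a clear fall again here. Measured across both extensions, the change is a number 20 percentage points lower from compound 1 to compound 3 (beyond the scatter) and lies clearly outside normal variation, so the longer chains of compound 2 and compound 3 sit together, apart from compound 1. Nothing available explains this dependence on chain length.

Three compounds cannot show whether a still longer chain would stay at this level or change it. Also open, from the compounds shown here alone, is how the same position would respond to a branched chain, or to a chain ending in an amine or a carboxylic acid, and whether an amide in place of the ester would alter the picture.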